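Three measured glycoside ethers and one expected value

This account rests on a few compounds, and the source may have more. Where it says the series, first, only, none or still open, it means among the compounds named here.

Three compounds share a sugar-derived core that carries two aryl ether arms, and all three were measured in a functional assay on A549 cells (Homo sapiens) for cytotoxicity, read by MTT assay, with a stated time of 48 h; on this read-out lower numbers stand for an effect already at smaller amounts and higher numbers for an effect only at larger amounts of compound. Compound 1 `CO[C@@H]1O[C@H](COc2cccc(C(C)C)c2)[C@@H](O)[C@H](O)[C@H]1Oc1ccc(OC2CCCCC2)cc1` gives 41000 nM in this assay. Compound 2 `CO[C@@H]1O[C@H](COc2ccccc2C(C)C)[C@@H](O)[C@H](O)[C@H]1Oc1ccc(OC2CCCCC2)cc1` gives 41000 nM in this assay. The change between them, (2-isopropylphenyl in place of 3-isopropylphenyl on an oxygen on a saturated carbon), produced no change at the digits printed from compound 1 to compound 2 (within the scatter). Compound 3 `CO[C@H]1O[C@H](COc2ccc(-c3ccccc3)cc2)[C@@H](O)[C@H](O)[C@H]1Oc1cccc(C(C)C)c1` gives 32000 nM in this assay; its values and those of compound 1 and compound 2 lie within the scatter of one another, so no order among the three can be read from them. The difference between the core of compound 3 and that of compound 1 is not broken down here.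

Compound 4 `CO[C@H]1O[C@H](COc2ccc(-c3ccccc3)cc2)[C@@H](O)[C@H](O)[C@H]1Oc1ccccc1C(C)C` has not yet been measured in this assay. It differs from compound 3 by 2-isopropylphenyl in place of 3-isopropylphenyl on an oxygen on a saturated carbon. This is the same kind of change as that from compound 1 to compound 2, though the place is not identical: in compound 3 the oxygen sits on a saturated carbon whose other neighbour is a saturated ring carbon, whereas in compound 1 that neighbour is a saturated chain carbon.

Because no change at the digits printed from compound 1 to compound 2 (within the scatter) showed no movement, the step of no change at the digits printed from compound 3 to compound 4 (within the scatter) is expected to be small as well. Compound 4 is therefore estimated at 32000 nM in this assay, within a range of 16000 nM to 64000 nM.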

Compound 4, half-maximal effective concentration: 33000 nM
Estimate against measurement, compound 4: 1.0-fold (0.01 log units) below; measured number inside the range.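

In this assay, placing 2-isopropylphenyl instead of 3-isopropylphenyl on the second core gave a 1.0-fold higher number from compound 3 to compound 4 (0.01 log units; within the scatter). Set beside the earlier step, this change reads the same on the two cores: the same change on two cores in this assay, no change at the digits printed (within the scatter) from compound 1 to compound 2 and a 1.0-fold higher number (0.01 log units; within the scatter) from compound 3 to compound 4, 1.0-fold (0.01 log units) apart, within the scatter of two such steps. This shows that a change with no visible effect on one core also had none on the other, but it does not show that a step of real size would carry over in the same way, since neither step rises above the scatter, and two cores say nothing about how the change would behave on any further core in the series.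

The compounds shown leave open whether anything placed on this ring can move the number in this assay, as the isopropyl group is the only substituent compared here. An amine, a carboxylic acid or a longer chain in its stead might give a step large enough to test whether the effect of a change truly carries from one core to the other.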